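This account rests on a few compounds, and the source may have more. Where it says the series, first, only, none or still open, it means among the compounds named here.

In a functional assay on HaCaT cells (Homo sapiens), read by MTT assay, with a stated time of 48 h (a lower number here means a stronger inhibitor, a higher number a weaker inhibitor), compound 1 `CCc1noc(-c2ccc3c(c2)C(=O)C=CC3=O)n1` gives 14000 nM. Compound 2 `CCc1noc(-c2cc(C(C)=O)cs2)n1` stands at > 30000 nM, which is a limit of the assay and not a number. Compound 3 `CCc1noc(-c2cccs2)n1` departs from compound 2 by a single change: hydrogen in place of acetyl on an aromatic carbon. For the measured compounds named here, no two measured compounds in this assay differ in one place only, so the series gives no measured size for this change. No step beyond the scatter is expected in either direction, and another report at the limit of the assay is the more likely outcome. The expected move is a step that the limit leaves unreadable from compound 2 to compound 3. For compound 3 the estimated value is 40000 nM, with an expected range from 15000 nM to 100000 nM.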

Compound 3, half-maximal inhibitory concentration: > 30000 nM
Compound 3: only a limit was reported; the forecaster's own chance of this, stated with the estimate: 70%; the middle value is on the limit's open side.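

No step can be read from compound 2 to compound 3, since each is reported only as a limit of the assay. The compounds shown leave open how far either lies past that limit, and so what replacing acetyl with hydrogen does to the value.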